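From Dichlorophenyl to Dimethoxyphenyl at the Carbonyl

A few compounds are considered here, and "the series" means these few. Any claim that something is new, unique, unknown or untested is made for them only; others in the source may bear on it.

Of the compounds shown here, two built on the same core have been measured so far. Compound 1 `COc1cc(-c2cc(/C=C/C(=O)c3ccc(Cl)c(Cl)c3)[nH]n2)cc(OC)c1OC` gives 3390 nM in a functional assay on LOX IMVI cells (Homo sapiens) for inhibition, read by sulforhodamine B assay, with a stated time of 48 h (on this read-out lower numbers stand for stronger inhibition of growth and higher numbers for weaker inhibition of growth), and compound 2 `COc1ccc(-c2cc(/C=C/C(=O)c3cc(OC)c(OC)c(OC)c3)[nH]n2)cc1OC` gives 1460 nM in this assay. Going by the values given here, compound 1 thus stands at the weaker end of the two numbers, with compound 2 the only neighbour and its value beyond the scatter below that of compound 1.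

Compound 3 `COc1ccc(C(=O)/C=C/c2cc(-c3cc(OC)c(OC)c(OC)c3)n[nH]2)cc1OC` has not yet been measured. It differs from compound 1 in one place: 3,4-dimethoxyphenyl in place of 3,4-dichlorophenyl on a carbonyl carbon. Among the compounds with values here, there is no measured pair that isolates this exact change, so the expectation can rest only on the two values shown. Compound 2, which carries oxygen-bearing groups on both aryl rings, sits below compound 1, and the change in compound 3 moves in that direction by replacing the chlorines with methoxy groups. Compound 3 is therefore expected to give a modestly lower number, with the step of a 1.7-fold lower number from compound 1 to compound 3 (0.23 log units; within the scatter) estimated to be small but in the direction of stronger inhibition. The value of compound 3 in this assay is estimated at 2000 nM, within a range from 800 nM to 5500 nM.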

Compound 3, concentration for 50% growth inhibition: 1380 nM
Estimate against measurement, compound 3: 1.4-fold (0.16 log units) above; the range from low to high includes it.
By their numbers in this assay, from the lowest: compounds 3 and 2 (each within the scatter of the next); then compound 1.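

In this assay, going by these compounds alone, this is the first step in the set that isolates a single place: 3,4-dimethoxyphenyl in place of 3,4-dichlorophenyl on a carbonyl carbon gives a 2.5-fold lower number from compound 1 to compound 3 (0.39 log units; beyond the scatter). Everything else in compound 1 stays as it is, so this gap belongs to that one exchange and shows that the group on the carbonyl carbon matters on this read-out, which the two earlier values, with no single-place step between them, could not show. Nothing measured here accounts for the shift, so the data give its size and direction but no explanation for it.

As far as these compounds go, a single step cannot separate what the two methoxy groups contribute from what the loss of the two chlorines contributes, so it remains open whether the lower number follows from adding one or removing the other. Also open, from the compounds shown here alone, is how this position would respond to a plain phenyl, a 3,4-difluorophenyl, a 4-methoxyphenyl or a 3,4,5-trimethoxyphenyl on the same carbonyl carbon, with the rest of the compound held constant.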